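Thiomorpholine to piperidine on the thiocarbonyl carbon

The source may report more compounds than this note shows. Statements on the series, on what has been measured and on what is new or still open speak of the compounds shown alone.

Measured compounds:
Compound 1 `Cc1ccnc(/C(N)=N/NC(=S)N2CCOCC2)c1` gives 5.07% in a functional assay on MCF7 cells (Homo sapiens) for cytotoxicity, read by MTT assay, with a stated time of 72 h, tested at 3 uM; a higher number here means more inhibition of growth at the concentration tested, a lower number less inhibition of growth.
Compound 2 `Cc1cccc(/C(N)=N/NC(=S)N2CCSCC2)n1` gives 20.6% in this assay.
Compound 3 `N/C(=N\NC(=S)N1CCSCC1)c1ccccn1` gives 29% in this assay.

Compound 2 stands second highest of the three numbers. Within the data shown here, compound 1 lies furthest from it, lower and beyond the scatter, but differs from compound 2 in two places, so no single step is drawn between them. Among the measured compounds shown here, the one single-place step available is a number 8.4 percentage points higher from compound 2 to compound 3 (within the scatter), hydrogen in place of methyl on an aromatic carbon, and it stays within the scatter.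

Compound 4 `Cc1cccc(/C(N)=N/NC(=S)N2CCCCC2)n1` is not yet measured. It differs from compound 2 by piperidin-1-yl in place of thiomorpholin-4-yl on a thiocarbonyl carbon. For the measured compounds named here, no measured step exchanges the ring on the thiocarbonyl carbon, so nothing bears directly on this change; the only measured step touches the aromatic ring and is within the scatter. Therefore no step beyond the scatter is expected in this assay in either direction, and the range is kept wide for lack of precedent. For compound 4 the estimate is 18%, range 4% to 34%. This estimate means an expected step of a number 2.6 percentage points lower from compound 2 to compound 4 (within the scatter).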

Compound 4, percent growth inhibition at one concentration: 27.1%
Beside the measured number, compound 4's estimate is 9.1 percentage points below it; low and high end bracket the measured number.
By their numbers in this assay, from the lowest: compound 1; then compounds 2, 4 and 3 (each within the scatter of the next).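

In this assay, the exchange of thiomorpholin-4-yl for piperidin-1-yl on the thiocarbonyl carbon gives a number 6.5 percentage points higher from compound 2 to compound 4 (within the scatter). This is the only step shown that changes the ring at this position, and it changes the group itself, not the aromatic ring touched by the earlier step. In this one pair, the ring sulfur can be absent without a step beyond the scatter, so the position accepts this exchange, though the pair says nothing about any other ring; no measured data are available to explain the result.

Open, as far as these compounds go, is whether a ring is needed on the thiocarbonyl carbon at all, which a dimethylamino group there would test, and how a piperazine with its second ring nitrogen carrying hydrogen would read out. Also open, from the compounds shown here alone, is whether the exchange behaves alike on the core of compound 3.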